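Methylsulfanyl on the benzyl ring of a quinazoline-type core

The source may report more compounds than this note shows. Statements on the series, on what has been measured and on what is new or still open speak of the compounds shown alone.

Measured compounds:
compound 1 `CCCCC[Se]c1nc(NCc2ccc(SC)cc2)c2ccccc2n1` – 35000 nM
compound 2 `Sc1nc(NCc2ccccc2)c2ccccc2n1` – 82400 nM
compound 3 `CSc1nc(NCc2ccccc2)c2ccccc2n1` – 87900 nM

In a functional assay on CCRF-CEM cells (Homo sapiens) for cytotoxicity, read by MTT assay, with a stated time of 72 h (a lower number here means a stronger inhibitor of growth, a higher number a weaker inhibitor of growth), compound 3 gives 87900 nM, the highest of the three numbers. Compound 2 lies nearest, and a 1.1-fold higher number from compound 2 to compound 3 (0.03 log units; within the scatter). Compound 1, which carries a pentyl chain on selenium and a methylsulfanyl on its benzyl ring, stands furthest away with 35000 nM, a number beyond the scatter from that of compound 3, but compound 1 differs from compound 3 in two places, so its value cannot be tied to either change alone.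

Compound 4 `CSc1ccc(CNc2nc(SC)nc3ccccc23)cc1` is not yet measured. It keeps the core of compound 3 and differs by methylsulfanyl in place of hydrogen on an aromatic carbon. For the measured compounds named here, no measured pair isolates this change: the only single-place step in hand is that from compound 2 to compound 3, a swap on the sulfur of the core that stayed within the scatter, and it bears only indirectly on a change on the benzyl ring. The lower number of compound 1 is the sole hint that a methylsulfanyl on that ring could go with a lower number.

For compound 4 in this assay the expected outcome is a step of a 1.6-fold lower number from compound 3 to compound 4 (0.20 log units; within the scatter), with an estimate of 55000 nM and a likely range from 20000 nM to 150000 nM.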

Compound 4, concentration for 50% growth inhibition: > 100000 nM
Compound 4: no number, only a limit (the forecaster's own chance of this, stated with the estimate: 10%); at least 1.8-fold (0.25 log units) between middle value and limit.
By their numbers in this assay, from the lowest: compound 1; then compounds 2 and 3 (each within the scatter of the next). At a limit, above all of these: compound 4.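

In this assay compound 4 gives no number, only a limit of the assay: the limit of > 100000 nM in this assay, at which 1 of the 4 values shown sits.

Going by these compounds, with methylsulfanyl in place of hydrogen on an aromatic carbon, para to a large group, the result is an at least 1.1-fold higher number from compound 3 to compound 4 (0.05 log units; that floor lies within the scatter), so this change shows no sign of a lower number on this scaffold, although the true size of the step remains unknown. With methylsulfanyl on the benzyl ring in both compounds, the exchange of the group on the core gives an at least 2.8-fold higher number from compound 1 to compound 4 (0.45 log units; beyond the scatter), which ties the lower number of compound 1 to its pentyl chain on selenium and not to the ring group alone.

The compounds shown do not separate the part played by the selenium from that of the pentyl chain, since a pentyl chain on sulfur and a methyl on selenium are both absent from this set. They also leave open whether another group at the same ring position, such as a methoxy, an amine or a carboxylic acid, would give a measurable number in this assay, and whether methylsulfanyl on the ring has any effect when the longer chain stays on the core.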